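This account rests on a few compounds, and the source may have more. Where it says the series, first, only, none or still open, it means among the compounds named here.

Measured so far in a functional assay on the whole organism for antagonist activity, with Mus musculus as the target, in the maximal electroshock model; a higher number here means that more compound is needed for the effect, a lower number that less compound is needed:

- compound 1 `Cc1ccc(-c2nnc([S+](C)[O-])n2C)cc1`, reported only as a limit of the assay: > 200 mg/kg
- compound 2 `Cc1ccc(-c2nnc(S(C)(=O)=O)n2C)cc1`, likewise only a limit of the assay: > 200 mg/kg
- compound 3 `Cn1nc([S+](C)[O-])nc1-c1ccccc1`, again only a limit of the assay: > 200 mg/kg

Compound 4 `Cn1nc(S(C)(=O)=O)nc1-c1ccccc1` has not yet been measured in this assay.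

Going by the values given here, the one change measured so far is that from compound 1 to compound 2: a group of 4 heavy atoms (1 carbon, 2 oxygen, 1 sulfur; no ring) in place of a group of 3 heavy atoms (1 carbon, 1 oxygen, 1 sulfur; no ring), on an aromatic carbon. Its size is a step that the two limits leave unreadable from compound 1 to compound 2. Among the compounds with values here, the only evidence bearing on it is the limit of > 200 mg/kg in this assay, at which 3 of the 3 values shown sit.

The change proposed from compound 3 to compound 4 is a group of 4 heavy atoms (1 carbon, 2 oxygen, 1 sulfur; no ring) in place of a group of 3 heavy atoms (1 carbon, 1 oxygen, 1 sulfur; no ring), on an aromatic carbon. Within the data shown here, it is the same kind of change as the one from compound 1 to compound 2, not the same: in the first the entering group sits next to the ring atom that bears a methyl group, whereas in the second it sits two ring bonds from the ring atom that bears a methyl group. The difference between the core of compound 1 and the core of compound 3 is not broken down here.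

The step from compound 3 to compound 4 in this assay is expected to be a step that the limit leaves unreadable from compound 3 to compound 4, set beside a step that the two limits leave unreadable from compound 1 to compound 2; this expectation rests on (the limit of > 200 mg/kg in this assay, at which 3 of the 3 values shown sit). Compound 4 is accordingly estimated at 300 mg/kg, with a range from 200 mg/kg to 800 mg/kg, and most probably it will again be reported only as a limit of the assay.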

Compound 4, dose for half-maximal effect: > 200 mg/kg
Compound 4 gave a limit, no number (the forecaster's own chance of this, stated with the estimate: 85%); the middle value lies beyond the limit too.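

In this assay compound 4 gives > 200 mg/kg, which is a limit of the assay. No step can be read between compound 3 and compound 4, nor between compound 1 and compound 2. The compounds shown leave open whether the methylsulfonyl group differs in effect from the group it replaces, and whether the two cores differ at all: the limit of > 200 mg/kg in this assay, at which 4 of the 4 values shown sit.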